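This account rests on a few compounds, and the source may have more. Where it says the series, first, only, none or still open, it means among the compounds named here.

Compound 1 `COc1ccccc1/C=C(\C(=O)c1ccc(Cl)cc1)S(=O)(=O)c1ccc(C)cc1` gives 1000 nM in a functional assay on DU-145 cells (Homo sapiens) for inhibition, read by trypan blue exclusion, with a stated time of 96 h; a lower number here means a stronger inhibitor of growth, a higher number a weaker inhibitor of growth.
Compound 2 `Cc1ccc(S(=O)(=O)/C(=C/c2ccc(C)s2)C(=O)c2ccc(Cl)cc2)cc1` gives 50000 nM in this assay.
Compound 3 `COc1ccccc1/C=C(/Sc1ccc(C)cc1)C(=O)c1ccc(Br)cc1` gives 9000 nM in this assay.

All three compounds share a chain in which two double-bonded carbons carry an aromatic ring on one side and a carbonyl on the other. Compound 2 differs from compound 1 in a single place: 5-methylthiophen-2-yl in place of 2-methoxyphenyl on a double-bonded chain carbon bound to a double-bonded chain carbon. That one change made a large step, a 50-fold higher number from compound 1 to compound 2 (1.70 log units; beyond the scatter), so the compound with the thiophene ring is the much weaker growth inhibitor of the pair.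

Compound 3 has a different core from compound 1, and the difference between the two cores is not broken down here. What the two values show is that compound 3 is a weaker inhibitor than compound 1 and a stronger one than compound 2.

Compound 4 `Cc1ccc(S/C(=C/c2ccc(C)s2)C(=O)c2ccc(Br)cc2)cc1` has not yet been measured. It differs from compound 3 in one place: 5-methylthiophen-2-yl in place of 2-methoxyphenyl on a double-bonded chain carbon bound to a double-bonded chain carbon. Going by the values given here, this is the same change, at the same place, as the one from compound 1 to compound 2. The step from compound 3 to compound 4 is expected to be a 28-fold higher number from compound 3 to compound 4 (1.44 log units; beyond the scatter) because the same change earlier gave a 50-fold higher number from compound 1 to compound 2 (1.70 log units; beyond the scatter). Compound 4 is therefore expected to give about 250000 nM in this assay, somewhere between 50000 nM and 1000000 nM. Since compound 3 already starts from a weak value, there is a fair chance that the assay reports only a limit for compound 4 rather than a number.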

Compound 4, concentration for 50% growth inhibition: > 100000 nM
Compound 4: no number, only a limit (the forecaster's own chance of this, stated with the estimate: 40%); the middle value does not contradict the limit.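

In this assay compound 4 gives > 100000 nM, which is a limit of the assay and not a number. Putting 5-methylthiophen-2-yl in place of 2-methoxyphenyl gives an at least 11-fold higher number from compound 3 to compound 4 (1.04 log units; beyond the scatter), so on both cores shown the change goes the same way, towards a much weaker inhibitor of growth. This does not show that the size of the step carries over from one core to the other, since only one of the two steps has a definite size: the same change on two cores in this assay, a 50-fold higher number (1.70 log units; beyond the scatter) from compound 1 to compound 2 and an at least 11-fold higher number (1.04 log units; beyond the scatter) from compound 3 to compound 4; the limit leaves it open whether they differ

The compounds shown leave open which part of the entering group goes with the loss of growth inhibition, the five-membered ring itself or its methyl, and a thiophen-2-yl without that methyl would separate the two. They also leave open how other groups would behave on a double-bonded chain carbon bound to a double-bonded chain carbon, such as a plain phenyl or a phenyl carrying an amine or a carboxylic acid, and whether the same trend would hold for them on both cores.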